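The source may report more compounds than this note shows. Statements on the series, on what has been measured and on what is new or still open speak of the compounds shown alone.

Measured values in a functional assay on SK-BR-3 cells (Homo sapiens) for cytotoxicity, read by sulforhodamine B assay, with a stated time of 3 days (a higher number here means that more compound is needed for the effect, a lower number that less compound is needed), are these
Compound 1 `CCOCc1c(C)coc1-c1ccc2c(c1OC)CCCC2(C)C` gives 19.8 uM
Compound 2 `CCc1cccc2c(O)c(-c3occ(C)c3C(=O)O)ccc12` gives 3.4 uM
Compound 3 `CCOc1c(-c2occ(C)c2CO)ccc2c1CCCC2(C)C` gives 9.9 uM

Compound 1 lies within the usual scatter of compound 3, and its number is higher than that of compound 2 by a margin beyond the scatter. Compound 4 `COCc1c(C)coc1-c1ccc2c(c1OC)CCCC2(C)C` differs from compound 1 by a single small edit, (hydrogen in place of methyl on a saturated chain carbon bound to an oxygen on a saturated carbon), with hydrogen in place of methyl on a saturated chain carbon bound to an oxygen on a saturated carbon. This turns ethoxymethyl into methoxymethyl. Among the compounds with values here, no measured pair here isolates one such change, so the data give no direct guide, and no step beyond the scatter is expected in this assay here. The expected 1.1-fold lower number from compound 1 to compound 4 (0.04 log units; within the scatter) is a small one. Compound 4 is estimated at 18 uM in the middle, with 8 uM to 40 uM as its expected range.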

Compound 4, concentration for half-maximal effect: 18.5 uM
The estimate for compound 4 lay 1.0-fold (0.01 log units) below the measured number; measured number inside the range.
By their numbers in this assay, from the lowest: compound 2; then compounds 3, 4 and 1 (each within the scatter of the next).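

In this assay, within the data shown here, the step of a 1.1-fold lower number from compound 1 to compound 4 (0.03 log units; within the scatter) is the first in this set that isolates a single change. It shows that, on the core of compound 1, shortening ethoxymethyl to methoxymethyl leaves the number within the scatter, so this one methyl makes no measurable difference here. Nothing measured here speaks to the reason for this. As far as these compounds go, what a longer chain, such as butoxymethyl, or an amine at this place would do remains open, so the tolerance seen covers only this small edit.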